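Aryl swap at the aromatic carbon in a lactone series

This account rests on a few compounds, and the source may have more. Where it says the series, first, only, none or still open, it means among the compounds named here.

Measured so far in an assay for inhibition of 3-hydroxy-3-methylglutaryl-coenzyme A reductase (Rattus norvegicus); on this read-out higher numbers stand for weaker inhibition and lower numbers for stronger inhibition:
compound 1, `CC(C)c1nc(C(C)(C)C)cc(-c2ccc(F)cc2)c1/C=C/[C@@H]1C[C@@H](O)CC(=O)O1`, gives 1 nM
compound 2, `CC(C)c1nc(-c2ccc(F)cc2)cc(-c2ccc(F)cc2)c1/C=C/[C@@H]1C[C@@H](O)CC(=O)O1`, gives 2 nM

Among the compounds with values here, compound 2 sits at one end of this pair of numbers, but the only step measured, a 2.0-fold higher number from compound 1 to compound 2 (0.30 log units; within the scatter), lies within the scatter, so compound 1 and compound 2 cannot be told apart on this assay.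

Compound 3, `Cc1ccc(C)c(-c2cc(-c3ccc(F)cc3)c(/C=C/[C@@H]3C[C@@H](O)CC(=O)O3)c(C(C)C)n2)c1`, is the next compound to be measured. It differs from compound 2 in one place: 2,5-dimethylphenyl in place of 4-fluorophenyl on an aromatic carbon. Within the data shown here, the single step on record touches the same aromatic carbon, exchanging tert-butyl for 4-fluorophenyl, and it changed the number only by a 2.0-fold higher number from compound 1 to compound 2 (0.30 log units; within the scatter). Among the measured compounds shown here, no step tests a 2,5-dimethylphenyl group anywhere, so the guidance is thin and the range must stay wide.

For compound 3 the expected step from compound 2 is a 1.5-fold higher number from compound 2 to compound 3 (0.18 log units; within the scatter), i.e. nothing beyond the scatter. Compound 3 is therefore estimated at 3 nM, with a range from 1 nM to 12 nM.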

Compound 3, half-maximal inhibitory concentration: 5 nM
Estimate against measurement, compound 3: 1.7-fold (0.22 log units) below, and the stated range covers the measured number.
By their numbers in this assay, from the lowest: compounds 1 and 2 (each within the scatter of the next); then compound 3.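

In this assay this position, next to the ring nitrogen, now shows steps beyond the scatter: the exchange of 4-fluorophenyl for 2,5-dimethylphenyl gives a 2.5-fold higher number from compound 2 to compound 3 (0.40 log units; beyond the scatter) and the exchange of tert-butyl for 2,5-dimethylphenyl gives a 5.0-fold higher number from compound 1 to compound 3 (0.70 log units; beyond the scatter) and both are modest. The carbon is therefore not indifferent to its substituent: tert-butyl and 4-fluorophenyl could not be told apart here, whereas 2,5-dimethylphenyl, which has 8 heavy atoms against the 7 of 4-fluorophenyl and carries no fluorine, gives weaker inhibition than either of them. Nothing measured on these compounds connects this loss to any particular feature of the new group, so the shift remains a plain observation on three compounds.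

The compounds shown leave open whether the loss needs both methyl groups, which a phenyl carrying a single methyl group or an unsubstituted phenyl would help to separate. Also open, on these data alone, is how the position responds to groups of a different kind, such as an amine, a carboxylic acid or a longer alkyl chain, since only hydrocarbon and fluorinated aryl substituents appear here.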